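The compounds below may be only part of what the source reports. "The series", "measured", "known", "first", "only" and "open" are said of these compounds alone.

In a physicochemical assay for solubility, using the shake flask method, in phosphate buffer, with a stated time of 20 h, at pH 6.5 (on this read-out lower numbers stand for lower solubility and higher numbers for higher solubility), compound 3 (`C[S+]([O-])c1ccc(-c2cnc3ccc(Nc4cccc([S+](C)[O-])c4)nn23)cc1`) gives 190000 nM, within the usual scatter of compound 1 (`CCN(CC)Cc1ccc(-c2ccc3ncc(-c4ccc([S+](C)[O-])cc4)n3n2)c(F)c1`) at 180000 nM. Compound 2 (`C[S+]([O-])c1ccc(-c2cnc3ccc(Nc4cccc(S(C)(=O)=O)c4)nn23)cc1`) gives 20000 nM. Among the compounds with values here, the one measured step, a 9.5-fold higher number from compound 2 to compound 3 (0.98 log units; beyond the scatter), swaps only a small sulfur-bearing group on the aromatic ring. Compound 4 (`C[S+]([O-])c1ccc(-c2cnc3ccc(NC4CCS(=O)(=O)CC4)nn23)cc1`) goes further, with a group of 8 heavy atoms (5 carbon, 2 oxygen, 1 sulfur; one six-membered non-aromatic ring with 1 hetero atom) in place of a group of 9 heavy atoms (7 carbon, 1 oxygen, 1 sulfur; one six-membered aromatic ring of carbon only), on a nitrogen on an aromatic ring. That aromatic ring is gone, and 1,1-dioxothian-4-yl sits on the nitrogen. Within the data shown here, no measured step covers such a swap, so a 9.5-fold higher number from compound 2 to compound 3 (0.98 log units; beyond the scatter) serves only as a rough guide to how far a change in this part can move the number. The expected result is a 1.6-fold lower number from compound 3 to compound 4 (0.20 log units; within the scatter), so no shift beyond the scatter is expected, although the uncertainty is wide. For compound 4 the estimate is 120000 nM, with an expected range from 40000 nM to 300000 nM.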

Compound 4, solubility: 10000 nM
Beside the measured number, compound 4's estimate is 12-fold (1.08 log units) above it; the whole stated range lies above it.
By their numbers in this assay, from the lowest: compounds 4 and 2 (each within the scatter of the next); then compounds 1 and 3 (each within the scatter of the next).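

In this assay the change on the nitrogen gives a 19-fold lower number from compound 3 to compound 4 (1.28 log units; beyond the scatter) when 1,1-dioxothian-4-yl replaces the group with the six-membered aromatic ring of carbon only. Compound 4 at 10000 nM lies within the scatter of compound 2 at 20000 nM and so does not keep the high number of compound 3, showing that a non-aromatic ring in this place need not hold that number. No measurement shown here accounts for the drop.
As far as these compounds go, it remains open whether a piperidine ring bearing an amine or a carboxylic acid, placed on the same nitrogen, would give a number nearer compound 3 or compound 4.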